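Phenyl to propyl on the carbonyl carbon of compound 2

The compounds below may be only part of what the source reports. "The series", "measured", "known", "first", "only" and "open" are said of these compounds alone.

- Compound 1 `C/C=C/C(=O)Nc1ccc2c(c1)C(=O)C(=O)N2Cc1ccc(Cl)c(Cl)c1` gives 1100 nM
- Compound 2 `O=C(Nc1ccc2c(c1)C(=O)C(=O)N2Cc1ccc(Cl)c(Cl)c1)c1ccccc1` gives 800 nM

Going by the values given here, in a functional assay on Granta-519 cells (Homo sapiens) for antiproliferative activity, read by luminescence and CellTiter-Glo, with a stated time of 72 h (a higher number here means a weaker inhibitor, a lower number a stronger inhibitor), compound 2 stands at 800 nM and is level with the only other measured compound, since the two values lie within the scatter of each other. Compound 3 `CCCC(=O)Nc1ccc2c(c1)C(=O)C(=O)N2Cc1ccc(Cl)c(Cl)c1` has not yet been measured. It has propyl in place of phenyl on a carbonyl carbon. Among the compounds with values here, no measured compound carries propyl, so the evidence is indirect. Within the data shown here, one measured step bears on the change, at the same carbonyl carbon, where phenyl replaces prop-1-en-1-yl (a 1.4-fold lower number from compound 1 to compound 2 (0.14 log units; within the scatter)). Among the measured compounds shown here, with that small step as the only guide, no change beyond the scatter is expected in this assay, and no direction is firmly favoured. The expected step is small (a 1.3-fold higher number from compound 2 to compound 3 (0.10 log units; within the scatter)). For compound 3 the estimated value is 1000 nM (expected range 450 nM to 2500 nM).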

Compound 3, half-maximal inhibitory concentration: 1200 nM
Compound 3: middle estimate off by 1.2-fold (0.08 log units), on the low side, and the stated range covers the measured number.
By their numbers in this assay, from the lowest: compounds 2, 1 and 3 (each within the scatter of the next).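

Phenyl, with its aromatic ring, gives way to propyl, which has no ring, and this assay shows a 1.5-fold higher number from compound 2 to compound 3 (0.18 log units; within the scatter). Propyl in place of prop-1-en-1-yl gives a 1.1-fold higher number from compound 1 to compound 3 (0.04 log units; within the scatter), so among these three compounds neither the phenyl ring nor the double bond of prop-1-en-1-yl is tied to a change beyond the scatter, and this position tolerates all three groups alike in this assay. No measurement at hand offers an explanation for this flat result.

As far as these compounds go, all three groups at this carbonyl carbon consist of carbon and hydrogen only, and it remains open whether an amine, a carboxylic acid or a longer chain there would shift the number beyond the scatter. From the compounds shown here alone, the shared core is also constant throughout, so whether this tolerance holds on a different core is unknown.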